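Pyrimidin-2-yl replacing ethyl on the piperazine nitrogen

The source may hold more compounds than are shown below. What is called first, only, known or untested is meant among the compounds shown, and "the series" means these compounds.

The account follows three measured compounds and one awaiting its number. Compound 2 `CCN1CCN(C(=O)/C=C/C=C/[C@H](O)Cc2ccc(OC)c(OC)c2)CC1` gives, in a functional assay on IMR-32 cells (Homo sapiens) for antiproliferative activity, read by sulforhodamine B assay, with a stated time of 48 h (on this read-out higher numbers stand for weaker inhibition and lower numbers for stronger inhibition), a value of 10800 nM. Compound 1 `COc1ccc(C[C@@H](O)/C=C/C=C/C(=O)N2CCN(c3ccccn3)CC2)cc1OC` gives in this assay a value of 11100 nM, and compound 3 `CCNC(=O)/C=C/C=C/[C@H](O)Cc1ccc(OC)c(OC)c1` gives in this assay a value of 9430 nM. Compound 2 stands second highest of the three, and both its neighbours lie within the scatter: a 1.0-fold lower number from compound 1 to compound 2 (0.01 log units; within the scatter) and a 1.1-fold lower number from compound 2 to compound 3 (0.06 log units; within the scatter). Compound 4 `COc1ccc(C[C@@H](O)/C=C/C=C/C(=O)N2CCN(c3ncccn3)CC2)cc1OC` differs from compound 2 in one place: pyrimidin-2-yl in place of ethyl on an amine nitrogen in a ring. The step from compound 1 to compound 2, which swapped a pyridin-2-yl for an ethyl at the same ring nitrogen, produced no change beyond the scatter, and the step from compound 2 to compound 3 at the carbonyl carbon likewise stayed within it. Putting a pyrimidin-2-yl in that position is therefore expected to leave this assay essentially unmoved, with an expected step of a 1.0-fold higher number from compound 2 to compound 4 (0.01 log units; within the scatter). Compound 4 is estimated at 11000 nM, within a range from 5500 nM to 22000 nM.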

Compound 4, half-maximal inhibitory concentration: 10800 nM
Compound 4: the middle estimate sits 1.0-fold (0.01 log units) above what was measured; measured number inside the range.
By their numbers in this assay, from the lowest: compounds 3, 2, 4 and 1 (each within the scatter of the next).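

At this amine nitrogen in a ring, one six-membered aromatic ring with 2 hetero atoms takes the place of ethyl, yet this assay shows no difference beyond the scatter: no change at the digits printed from compound 2 to compound 4 (within the scatter). The earlier compounds shown here had compared only pyridin-2-yl with ethyl here; the exchange of one aromatic ring for another adds a further comparison, a 1.0-fold lower number from compound 1 to compound 4 (0.01 log units; within the scatter), so that ethyl, pyridin-2-yl and pyrimidin-2-yl all stand within the scatter of one another at this position. Nothing measured here bears on why these groups read alike.

On these data alone, whether a carboxylic acid or a longer chain on this nitrogen would move the number beyond the scatter stays open. So does whether any change to the shared core, rather than to this group, would do so.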